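Swapping a chlorophenyl for a methoxyphenoxy group

The compounds below may be only part of what the source reports. "The series", "measured", "known", "first", "only" and "open" are said of these compounds alone.

Of the compounds shown here, three sharing one core have been measured in a functional assay on CHO cells for antagonist activity at prostaglandin E2 receptor EP1 subtype (Homo sapiens), read by FLIPR and calcium flux; on this read-out higher numbers stand for weaker inhibition and lower numbers for stronger inhibition. Compound 1, `CCc1ccccc1N(Cc1nnc(Cc2ccc(Cl)cc2)o1)S(=O)(=O)c1ccc(C)cc1`, gives 316 nM, the second highest of the three numbers. Compound 3, `Cc1ccc(S(=O)(=O)N(Cc2nnc(Cc3c(Cl)cccc3Cl)o2)c2cccc(Cl)c2C)cc1`, gives 501 nM, a number that lies within the usual scatter of compound 1, so the two cannot be told apart. Among the compounds with values here, compound 2, `COc1ccc(Cc2nnc(CN(c3cccc(Cl)c3Cl)S(=O)(=O)c3ccc(C)cc3)o2)cc1`, gives 39.8 nM, which is clearly lower than compound 1; since compound 2 differs from compound 1 in more than one place, no single step can be drawn between them.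

The change now followed leads from compound 1 to compound 4, `CCc1ccccc1N(Cc1nnc(COc2ccc(OC)cc2)o1)S(=O)(=O)c1ccc(C)cc1`. The difference is 4-methoxyphenoxy in place of 4-chlorophenyl on a saturated chain carbon bound to an aromatic carbon. Within the data shown here, no measured pair shows this particular change, so its effect has to be estimated rather than read off. A small shift toward stronger inhibition is expected in this assay, a step from compound 1 to compound 4 of about a 1.6-fold lower number from compound 1 to compound 4 (0.20 log units; within the scatter), but one that may well fall inside the scatter. Compound 4 is therefore expected to give roughly 200 nM, within a range from 60 nM to 700 nM.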

Compound 4, inhibition constant: 126 nM
Compound 4: the middle estimate sits 1.6-fold (0.20 log units) above what was measured; low and high end bracket the measured number.
By their numbers in this assay, from the lowest: compound 2; then compound 4; then compounds 1 and 3 (each within the scatter of the next).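

In this assay, putting 4-methoxyphenoxy in place of 4-chlorophenyl on a saturated chain carbon bound to an aromatic carbon gives a 2.5-fold lower number from compound 1 to compound 4 (0.40 log units; beyond the scatter), a modest step but one beyond the scatter. Within the data shown here, it is the first change in this set that can be read at a single place, and it shows that this position accepts a larger group carrying hydrogen-bond acceptors, where the group it replaces has none, without losing inhibition. Nothing measured here explains the step.

The step combines two changes, a new oxygen in the link and methoxy in place of chlorine on the ring, and 4-chlorophenoxy at this place would help tell them apart. From the compounds shown here alone, whether this position also accepts an amine or a carboxylic acid remains open.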